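Methyl added to the phenyl ring: cytotoxicity outlook

The source may report more compounds than this note shows. Statements on the series, on what has been measured and on what is new or still open speak of the compounds shown alone.

Compound 1 `O=c1nc(-c2ccccc2)c2cc(-c3cccnc3)ccc2[nH]1`: in an ADME assay on L6 cells (Rattus norvegicus) for cytotoxicity, read by fluorescence and resazurin assay, with a stated time of 72 h (on this read-out lower numbers stand for an effect already at smaller amounts and higher numbers for an effect only at larger amounts of compound), compound 1 gives > 50000 nM, which is a limit of the assay.
Compound 2 `O=c1nc(-c2ccccc2)c2cc(-c3cc[nH]n3)ccc2[nH]1`: compound 2 gives > 50000 nM, again a limit.
Compound 3 `Cc1ccc2[nH]c(=O)nc(-c3ccccc3)c2c1`: compound 3 gives > 50000 nM, also a limit.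

Compound 2 therefore stands at the limit, together with the other two values; all three sit at the limit of > 50000 nM in this assay, at which 3 of the 3 values shown sit. The steps among them, a step that the two limits leave unreadable from compound 1 to compound 2, a step that the two limits leave unreadable from compound 1 to compound 3 and a step that the two limits leave unreadable from compound 2 to compound 3, cannot be read from such limits.

Compound 4 `Cc1ccccc1-c1nc(=O)[nH]c2ccc(-c3cc[nH]n3)cc12` differs from compound 2 by methyl in place of hydrogen on an aromatic carbon. Since the measured steps bear on the change only through limits, no step beyond the scatter is expected; the step from compound 2 to compound 4 is estimated as a step that the limit leaves unreadable from compound 2 to compound 4. Compound 4 is expected to give 80000 nM, with a range from 40000 nM to 200000 nM.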

Compound 4, half-maximal effective concentration: > 50000 nM
Compound 4 ended at the assay's limit (the forecaster's own chance of this, stated with the estimate: 85%); the middle value does not contradict the limit.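

No step can be read from compound 2 to compound 4, as both values are limits of the assay: the limit of > 50000 nM in this assay, at which 4 of the 4 values shown sit.

The compounds shown leave open whether going from phenyl to 2-methylphenyl changes the effect in this assay at all.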